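The source may hold more compounds than are shown below. What is called first, only, known or untested is meant among the compounds shown, and "the series" means these compounds.

Of the compounds shown here, three have been measured in an assay on HEK293 cells for agonist activity at transient receptor potential cation channel subfamily M member 8 (Homo sapiens), read by fluorescence and calcium flux, with a stated time of 15 min; a lower number here means that less compound is needed, a higher number that more compound is needed for the effect. Compound 1 `CCc1ccc(OCC(=O)N(CC)Cc2cccs2)cc1` gives 67 nM. Compound 2 `CCN(Cc1cccs1)C(=O)c1cc2cc(C)ccc2s1` gives 1600 nM. Compound 3 `Cc1ccc(OCC(=O)N(Cc2cccs2)c2nccs2)cc1` gives 2240 nM, the highest of the three numbers; its value lies within the usual scatter of the number for compound 2, while the number for compound 1 is lower by a gap well beyond that scatter. Compound 4 `Cc1ccc(OCC(=O)N(O)Cc2cccs2)cc1` has not been measured yet. It differs from compound 3 in one place: hydroxy in place of 1,3-thiazol-2-yl on an amide-type nitrogen. Going by the values given here, no measured pair shows this exact change. A drop in the number is expected for compound 4 because compound 1, which also lacks 1,3-thiazol-2-yl on the amide-type nitrogen, gives 67 nM. The expected step is a moderate decrease, a 2.8-fold lower number from compound 3 to compound 4 (0.45 log units; beyond the scatter). Compound 4 is estimated at 800 nM, with a range from 200 nM to 4000 nM.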

Compound 4, half-maximal effective concentration: 8000 nM
Compound 4: the middle estimate sits 10-fold (1.00 log units) below what was measured; the measured number lies above the stated range.
By their numbers in this assay, from the lowest: compound 1; then compounds 2 and 3 (each within the scatter of the next); then compound 4.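

In this assay, hydroxy in place of 1,3-thiazol-2-yl on the amide-type nitrogen gives a clear rise (a 3.6-fold higher number from compound 3 to compound 4 (0.55 log units; beyond the scatter)). Going by these compounds alone, this is the first direct reading at this position, and it shows that trading a five-membered aromatic ring for a group of one heavy atom does not lower the number on this core. No available evidence explains the step. From the compounds shown here alone, whether the rise comes from losing the ring or from gaining the hydroxy stays open. A methyl or methoxy group on this nitrogen could help separate the two.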